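A few compounds are considered here, and "the series" means these few. Any claim that something is new, unique, unknown or untested is made for them only; others in the source may bear on it.

The series rests on a shared alpha-ketoamide core carrying a chloro-substituted phenethyl arm, and the question at hand is how much of the nitrogen-side substituent the activity in an assay on HEK-293T cells for inhibition of phospholipase A and acyltransferase 3 (Homo sapiens), with stated times of 30 min and 20 min (a higher number here means a weaker inhibitor, a lower number a stronger inhibitor), can spare. Compound 1 `O=C(CCc1ccc(Cl)cc1)C(=O)NCCCCc1ccccc1` gives 1000 nM in this assay. Compound 3 `O=C(CCc1ccc(Cl)cc1)C(=O)NCc1ccccc1` gives 1580 nM in this assay, a number that lies within the usual scatter of the result for compound 1, so the two cannot be told apart on these figures. Compound 2 `O=C(NCc1ccccc1)C(F)(F)C(O)CCc1ccccc1`, which carries a difluoro-hydroxy chain in place of the diketone, gives only a limit in this assay, > 10000 nM, and no number beyond that (the limit of > 10000 nM in this assay, at which 1 of the 3 values shown sits).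

Compound 4 `CCNC(=O)C(=O)CCc1ccc(Cl)cc1` is not yet measured. It differs from compound 3 in one place: methyl in place of phenyl on a saturated chain carbon bound to an amide-type nitrogen. The whole aromatic portion of the amide substituent is thus gone, leaving a short chain on the nitrogen. Among the measured compounds shown here, no measured pair in this set isolates that change, so its size must be judged from the fact that both compounds 1 and 3, which keep a phenyl on that side, sit near the same number. Compound 4 is expected to be a weaker inhibitor in this assay, with a step of a 3.8-fold higher number from compound 3 to compound 4 (0.58 log units; beyond the scatter), and its value is estimated at 6000 nM, between 2000 nM and 20000 nM.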

Compound 4, half-maximal inhibitory concentration: 7940 nM
The estimate for compound 4 lay 1.3-fold (0.12 log units) below the measured number; low and high end bracket the measured number.
By their numbers in this assay, from the lowest: compounds 1 and 3 (each within the scatter of the next); then compound 4. At a limit, above all of these: compound 2.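

In this assay, the nitrogen-side substituent proves not to be freely expendable, which compounds 1 and 3 could not show, as their results lie within the scatter of each other: cutting benzyl back to ethyl gives a 5.0-fold higher number from compound 3 to compound 4 (0.70 log units; beyond the scatter). Measured against the longer phenyl-bearing chain, the change gives a 7.9-fold higher number from compound 1 to compound 4 (0.90 log units; beyond the scatter), so both compounds that keep the phenyl stand apart from the ethyl amide by steps beyond the scatter, though both steps are modest and compound 4 still gives a number rather than a limit. Nothing in the data at hand gives a cause for this loss.

The compounds shown leave open whether the phenyl ring as such accounts for the step, or whether a cyclohexyl ring or a plain butyl chain on the nitrogen would serve equally well. They also leave open whether a phenyl carrying an amine or a carboxylic acid would hold the level of compounds 1 and 3, and how far the ethyl amide's result depends on the chloro group of the shared arm.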